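A few compounds are considered here, and "the series" means these few. Any claim that something is new, unique, unknown or untested is made for them only; others in the source may bear on it.

Measured compounds:
Compound 1 `Cc1cc(C)c2c(O)cc(-c3cccc4ccccc34)nc2n1` — 9550 nM in a functional assay on CAKI-1 cells (Homo sapiens) for antiproliferative activity; a lower number here means a stronger inhibitor of growth, a higher number a weaker inhibitor of growth
Compound 2 `Cc1ccc2c(O)cc(-c3cccc(Cl)c3)nc2n1` — 41.7 nM in this assay

Compound 2 has the lowest number of the two; in this assay compound 1 gives a number that stands far higher than compound 2, well beyond the scatter. The two compounds differ in more than one place, so this gap cannot be traced to a single change.

Compound 3 `Cc1cc(C)c2c(O)cc(-c3cccc(Cl)c3)nc2n1` has not yet been measured. It differs from compound 2 in one place: methyl in place of hydrogen on an aromatic carbon. Compound 1 also carries a methyl group at that place, but it differs from compound 2 in its aromatic substituent as well, so the two measured values on their own do not show what the methyl alone does.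

Among the measured compounds shown here, with no measured step in hand for this change, a modest shift is expected, more likely toward a higher number than a lower one, and possibly no shift beyond the scatter at all. The estimated step of a 2.4-fold higher number from compound 2 to compound 3 (0.38 log units; beyond the scatter) reflects this. Compound 3 is expected to give about 100 nM in this assay, within a range of 20 nM to 500 nM.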

Compound 3, concentration for 50% growth inhibition: 204 nM
Estimate against measurement, compound 3: 2.0-fold (0.31 log units) below; the range from low to high includes it.
By their numbers in this assay, from the lowest: compound 2; then compound 3; then compound 1.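

The step from hydrogen to methyl can now be read on its own: a 4.9-fold higher number from compound 2 to compound 3 (0.69 log units; beyond the scatter) in this assay is a change made at a single place. On this aromatic carbon, opposite the ring nitrogen, adding one methyl group therefore gives a weaker inhibitor of growth, and the shift lies beyond the scatter. Compound 3 also shows that the methyl does not by itself bring the number close to that of compound 1, since compound 3 gives 204 nM while compound 1, which carries the same methyl but a different aromatic substituent, gives 9550 nM in this assay.

Nothing in the data bears on why the number rises at this position.

The compounds shown hold only hydrogen or methyl at this place, so it remains open whether an ethyl group, a methoxy group or an amine would push the number higher or bring it back down. It is also open whether the methyl shifts the number by a similar amount alongside other aromatic substituents, as compound 1 has no partner lacking the methyl among the compounds shown.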